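The compounds below may be only part of what the source reports. "The series", "measured", "known", "first", "only" and "open" are said of these compounds alone.

Compound 3 `CNC(=O)C1(c2cc(F)cc(OCc3ccc(-n4ccnc4C)cc3)c2)CCOCC1` sits in the middle of three measured compounds. In an assay on blood for inhibition of Polyunsaturated fatty acid 5-lipoxygenase (Homo sapiens) (a higher number here means a weaker inhibitor, a lower number a stronger inhibitor), compound 3 gives 280 nM. Its neighbour compound 1 `Cc1nccn1-c1ccc(COc2cc(F)cc(C3(C(N)=O)CCOCC3)c2)cc1` gives 340 nM in this assay, and the gap a 1.2-fold lower number from compound 1 to compound 3 (0.08 log units; within the scatter) is too small to read as a real difference. Compound 2 `COC1(c2cc(F)cc(OCc3ccc(-n4ccnc4C)cc3)c2)CCOCC1` gives 60 nM in this assay, and the step of a 4.7-fold higher number from compound 2 to compound 3 (0.67 log units; beyond the scatter) shows that replacing the methoxy with a methylcarbamoyl costs potency. The same lesson comes from a 5.7-fold lower number from compound 1 to compound 2 (0.75 log units; beyond the scatter), where the carbamoyl gave way to a methoxy.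

Compound 4 `CSC1(c2cc(F)cc(OCc3ccc(-n4ccnc4C)cc3)c2)CCOCC1` has not yet been measured. It differs from compound 3 by methylsulfanyl in place of methylcarbamoyl on a saturated ring carbon. Like the methoxy of compound 2, the entering group is small and carries no hydrogen-bond donor, so the two measured steps away from amide-type groups are the ones that bear on this change. Both were modest and pointed toward lower numbers when the amide-type group was removed. A step of similar size, in the same direction, is therefore expected, a 3.1-fold lower number from compound 3 to compound 4 (0.49 log units; beyond the scatter). Compound 4 is expected to give about 90 nM in this assay, with a plausible range from 35 nM to 250 nM.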

Compound 4, half-maximal inhibitory concentration: 72 nM
Compound 4: the middle estimate sits 1.3-fold (0.10 log units) above what was measured; measured number inside the range.
By their numbers in this assay, from the lowest: compounds 2 and 4 (each within the scatter of the next); then compounds 3 and 1 (each within the scatter of the next).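

In this assay the change from methylcarbamoyl to methylsulfanyl gives a 3.9-fold lower number from compound 3 to compound 4 (0.59 log units; beyond the scatter) and the change from carbamoyl to methylsulfanyl gives a 4.7-fold lower number from compound 1 to compound 4 (0.67 log units; beyond the scatter) on the same saturated ring carbon, so methoxy no longer stands alone: two non-amide groups now give lower numbers than both amides. Exchanging the oxygen of the methoxy for the sulfur of the methylsulfanyl gives a 1.2-fold higher number from compound 2 to compound 4 (0.08 log units; within the scatter) and so cannot be told apart from no change at this position. The data offer no measured reason for the gap between the amides and these two groups.

Both amides differ from the methoxy and methylsulfanyl groups in more than one respect, as methylsulfanyl has fewer heavy atoms than methylcarbamoyl and no hydrogen-bond donor, so these compounds cannot show which of those differences matters. As far as these compounds go, a hydroxyl or an amine on this carbon would carry a donor on a small group, and a longer chain such as ethoxy would enlarge a group without one, so how either would behave remains open.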